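The source may report more compounds than this note shows. Statements on the series, on what has been measured and on what is new or still open speak of the compounds shown alone.

Working notes on the series. The shared core of compound 1 `CCCC[C@]1(CC)CS(=O)(=O)c2ccc(Br)cc2[C@@H](c2cccc(OC)c2)[C@H]1O` varies in the substituent on the fused aromatic ring and in the pendant aryl group. In an assay on cells for inhibition of ileal sodium/bile acid cotransporter (Homo sapiens) (a lower number here means a stronger inhibitor, a higher number a weaker inhibitor), compound 1 gives 70 nM. Compound 2 `CCCC[C@]1(CC)CS(=O)(=O)c2ccc(-c3ccccc3)cc2[C@@H](c2cccc(OC)c2)[C@H]1O` gives 180 nM in this assay. Compound 3 `CCCC[C@]1(CC)CS(=O)(=O)c2ccc(NO)cc2[C@@H](c2ccccc2)[C@H]1O` gives 260 nM in this assay, the highest of the three numbers; compound 2 stands nearest, within the scatter, and compound 1 furthest, beyond it. Compound 3 and compound 1 differ in two places, so their values show only that they differ.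

Compound 4 `CCCC[C@]1(CC)CS(=O)(=O)c2ccc(N(C)C)cc2[C@@H](c2ccccc2)[C@H]1O` is not yet measured. Its change from compound 3 is dimethylamino in place of hydroxyamino on an aromatic carbon. Among the compounds with values here, the only measured step at that aromatic carbon is a 2.6-fold higher number from compound 1 to compound 2 (0.41 log units; beyond the scatter), a modest change for an exchange of substituent at this place; no measured step exchanges one nitrogen-bearing substituent for another, and no measured compound carries dimethylamino. On that basis the step in this assay is expected to be small, a 1.3-fold lower number from compound 3 to compound 4 (0.11 log units; within the scatter), and may not exceed the scatter. Compound 4 is therefore estimated at 200 nM in this assay, with a range from 70 nM to 600 nM.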

Compound 4, half-maximal inhibitory concentration: 5 nM
Beside the measured number, compound 4's estimate is 40-fold (1.60 log units) above it; the measured number lies below the stated range.
By their numbers in this assay, from the lowest: compound 4; then compound 1; then compounds 2 and 3 (each within the scatter of the next).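

In this assay, within the data shown here, the exchange of hydroxyamino for dimethylamino on this aromatic carbon gives a 52-fold lower number from compound 3 to compound 4 (1.72 log units; beyond the scatter), a large step set against the modest 2.6-fold higher number from compound 1 to compound 2 (0.41 log units; beyond the scatter), the only earlier measured step at this place. The earlier compounds shown here showed only a modest response to an exchange of substituent here; this pair, with the pendant phenyl and the rest of the shared core unchanged, shows that the substituent at this carbon alone can shift the number strongly, and that the choice of nitrogen-bearing group matters. The exchange replaces a group with 2 hydrogen-bond donors by one with 0 and adds a heavy atom, but no measurement at hand bears on what lies behind the size of this step.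

Going by these compounds, whether the low number is specific to dimethylamino stays open, since a primary amine, a monomethylamino group or a diethylamino group at this carbon would separate the effect of the alkyl groups on nitrogen from that of the hydroxyl loss. Also open, on these data alone, is whether the step carries over to the methoxy-bearing pendant aryl group of compound 1, as compound 4 and compound 1 differ in two places.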